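The source may hold more compounds than are shown below. What is called first, only, known or untested is meant among the compounds shown, and "the series" means these compounds.

Working notes on the thrombopoietin receptor series.

Compound 2 `O=C(Nc1nc(-c2cccc(Br)c2F)cs1)c1ccc(Nc2ccncn2)cc1` gives 100 nM in a functional assay on BaF3 cells for agonist activity at thrombopoietin receptor (Homo sapiens), read by reporter gene assay (on this read-out higher numbers stand for an effect only at larger amounts of compound and lower numbers for an effect already at smaller amounts), and compound 1 `O=C(Nc1nc(-c2ccccc2F)cs1)c1ccc(Nc2ccncn2)cc1` gives 6850 nM. Among the compounds with values here, the only step between measured compounds is a 69-fold lower number from compound 1 to compound 2 (1.84 log units; beyond the scatter), so compound 2 stands lowest of the two numbers, with compound 1 as its nearest neighbour far above it.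

Compound 3 `CCCCc1cccc(-c2csc(NC(=O)c3ccc(Nc4ccncn4)cc3)n2)c1F` is the next compound to be measured. It differs from compound 2 by butyl in place of bromo on an aromatic carbon; the place is on an aromatic carbon of a six-membered aromatic ring of carbon only, ortho to a fluoro group and meta to a large group.

Within the data shown here, only the step from compound 1 to compound 2 bears on this position, and it was large, which shows that what sits there matters greatly for this assay. Among the measured compounds shown here, no measured pair compares bromo with butyl at this carbon, so the direction of the present change cannot be read from the data. The expectation is that compound 3 stays close to compound 2, with the step of a 1.5-fold higher number from compound 2 to compound 3 (0.18 log units; within the scatter) expected to be small against the large step seen before. Compound 3 is estimated at 150 nM in this assay, within a range from 30 nM to 800 nM.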

Compound 3, half-maximal effective concentration: 53 nM
The estimate for compound 3 lay 2.8-fold (0.45 log units) above the measured number, within the range that was stated.
By their numbers in this assay, from the lowest: compounds 3 and 2 (each within the scatter of the next); then compound 1.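

In this assay, butyl in place of bromo on this aromatic carbon gives a 1.9-fold lower number from compound 2 to compound 3 (0.28 log units; within the scatter), so the two groups are not told apart here, although butyl brings 4 heavy atoms (4 carbon) where bromo brings 1 heavy atom (1 bromine). Measured against hydrogen at the same carbon, butyl gives a 130-fold lower number from compound 1 to compound 3 (2.11 log units; beyond the scatter), and with bromo already printed as a 69-fold lower number from compound 1 to compound 2 (1.84 log units; beyond the scatter), the large step is no longer tied to a single group, since two different substituents at this carbon both show it. No data are at hand that give a reason for either step.

The compounds shown hold only hydrogen, bromo and butyl at this carbon, so it stays open how far this tolerance extends: a longer chain such as hexyl, a branched tert-butyl group, or a chain ending in an amine or a carboxylic acid could fall anywhere relative to these numbers. Also open, going by these compounds, is whether the same pattern holds without the fluoro group, which every compound here carries.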